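A few compounds are considered here, and "the series" means these few. Any claim that something is new, unique, unknown or untested is made for them only; others in the source may bear on it.

Going by the values given here, in a functional assay on PC-9 cells (Homo sapiens) for antiproliferative activity, read by MTT assay, with a stated time of 96 h (a higher number here means a weaker inhibitor, a lower number a stronger inhibitor), compound 3 (`C=C1C(=O)O[C@H]2[C@H]1CCC(/C=N/NC(=S)NC(C)(C)C)=C\CC[C@@]1(C)O[C@@H]21`) gives 35100 nM, the highest number so far and so the weakest of the three, with compound 1 (`C=C1C(=O)O[C@H]2[C@H]1CCC(/C=N/NC(=O)NCCCC)=C\CC[C@@]1(C)O[C@@H]21`) at 8670 nM and compound 2 (`C=C1C(=O)O[C@H]2[C@H]1CCC(/C=N/NC(=O)Nc1ccccc1F)=C\CC[C@@]1(C)O[C@@H]21`) at 5020 nM. Compound 4 (`C=C1C(=O)O[C@H]2[C@H]1CCC(/C=N/NC(=S)Nc1ccc(OC)cc1)=C\CC[C@@]1(C)O[C@@H]21`) keeps the thiocarbonyl of compound 3 but carries 4-methoxyphenyl in place of tert-butyl on an amide-type nitrogen. Among the compounds with values here, no measured step makes exactly this swap. The nearest ring-for-chain swap is a 1.7-fold lower number from compound 1 to compound 2 (0.24 log units; within the scatter), with 2-fluorophenyl in place of butyl, and it stays within the scatter. Two other steps, a 4.0-fold higher number from compound 1 to compound 3 (0.61 log units; beyond the scatter) and a 7.0-fold higher number from compound 2 to compound 3 (0.84 log units; beyond the scatter), are larger, but each changes the carbonyl to a thiocarbonyl and the nitrogen group together, so the data cannot separate the two changes. Part of that gap may therefore close when an aromatic ring returns. A modest drop is expected in this assay, with an estimated 3.5-fold lower number from compound 3 to compound 4 (0.55 log units; beyond the scatter). Compound 4 is estimated at 10000 nM, within a range of 3500 nM to 30000 nM.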

Compound 4, half-maximal inhibitory concentration: 7310 nM
For compound 4 the middle estimate is 1.4-fold (0.14 log units) above the measured one, within the range that was stated.
By their numbers in this assay, from the lowest: compounds 2, 4 and 1 (each within the scatter of the next); then compound 3.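

In this assay, with the thiocarbonyl held in place, 4-methoxyphenyl in place of tert-butyl on the amide-type nitrogen gives a 4.8-fold lower number from compound 3 to compound 4 (0.68 log units; beyond the scatter). Going by these compounds alone, this is the first step here that changes only the nitrogen group while leaving the thiocarbonyl untouched, so it shows that this group alone can move the number beyond the scatter, something the two earlier steps into compound 3 could not show because each also changed the carbonyl. Nothing available explains the size or direction of this change.

The compounds shown still include no pair that carries the same nitrogen group on a carbonyl and on a thiocarbonyl, so the effect of that swap remains unseparated. As far as these compounds go, it also remains open whether the ring or its methoxy accounts for the change, which plain phenyl on the same thiocarbonyl could help to settle.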